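Trimming a Dichlorophenyl Ether in a Dihydrofolate Reductase Series

This account rests on a few compounds, and the source may have more. Where it says the series, first, only, none or still open, it means among the compounds named here.

Compound 1 `NC1=NC2(CCOCC2)N(OCCCOc2ccccc2Cl)C(N)=N1`: 88.2%
Compound 2 `Cc1cc(C)cc(OCCCON2C(N)=NC(N)=NC23CCOCC3)c1`: 88.6%
Compound 3 `NC1=NC2(CCOCC2)N(OCCCOc2ccc(Cl)c(Cl)c2)C(N)=N1`: "not determined" (no result reported)

Two of the three measured compounds carry a number in an assay on isolated protein for inhibition of Dihydrofolate reductase (Homo sapiens), read by spectrophotometry, using NADPH, with stated times of 5 s and 6 min, tested at 50 uM; a lower number here means a weaker effect, a higher number a stronger effect of the compound at the concentration tested. In this assay compound 1 gives 88.2%, and compound 2 gives 88.6%. Among the compounds with values here, the only step between measured compounds that differ in one place is a number 0.4 percentage points higher from compound 1 to compound 2 (within the scatter), so exchanging the whole aryl group on the ether oxygen left the read-out where it was. Compound 3 has no result reported in this assay, so there is no single number on which it stands; its closest measured relatives, compound 1 and compound 2, sit together.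

Compound 4 `NC1=NC2(CCOCC2)N(OCCCOc2cccc(Cl)c2)C(N)=N1` differs from compound 3 in one place: hydrogen in place of chloro on an aromatic carbon. Within the data shown here, no measured step covers the loss of a single chloro group from this aryl ring. Among the measured compounds shown here, the step from compound 1 to compound 2 is the only guide, and it was within the scatter although it swapped the entire aryl group. On the strength of a number 0.4 percentage points higher from compound 1 to compound 2 (within the scatter), compound 4 is expected to fall in the same region, with no step beyond the scatter in either direction. Compound 4 is therefore estimated to give 85% in this assay, within a range from 68% to 96%.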

Compound 4, a percentage reported as inhibition, at one concentration (the size of the read-out at that concentration, not a potency): 85.8%
The estimate for compound 4 lay 0.8 percentage points below the measured number; the measured number falls inside the stated range.
By their numbers in this assay, from the lowest: compounds 4, 1 and 2 (each within the scatter of the next).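

In this assay the change to 3-chlorophenyl shows that the read-out holds with a single chloro group at a second place on the aryl ring: the swap from 3,5-dimethylphenyl gives a number 2.8 percentage points lower from compound 2 to compound 4 (within the scatter) and the swap from 2-chlorophenyl gives a number 2.4 percentage points lower from compound 1 to compound 4 (within the scatter) at the one concentration tested. Moving the lone chloro group therefore did as little as exchanging the whole aryl group had done, while the loss of chloro from 3,4-dichlorophenyl itself cannot be read, compound 3 having no number. No measurement shown here accounts for this flat picture.

All these numbers are read-outs at one concentration and not potencies, so compounds that sit together here could still differ at lower concentrations. Going by these compounds, it remains open whether the aryl ring would keep this read-out with an amine or a carboxylic acid in place of chloro, and whether a longer chain on the ether oxygen would leave it equally unmoved.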